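Chloro for methyl on the benzyl amide

A few compounds are considered here, and "the series" means these few. Any claim that something is new, unique, unknown or untested is made for them only; others in the source may bear on it.

Two compounds have numbers in an assay on microsomes from liver for inhibition of 3-hydroxy-3-methylglutaryl-coenzyme A reductase (Rattus norvegicus); on this read-out higher numbers stand for weaker inhibition and lower numbers for stronger inhibition. Compound 1 `CC(C)c1c(C(=O)N(C)Cc2ccccc2)nn(-c2ccc(F)cc2)c1CC[C@@H](O)C[C@@H](O)CC(=O)O` gives 6.2 nM. Compound 2 `Cc1ccc(CNC(=O)c2nn(-c3ccc(F)cc3)c(OC[C@@H](O)C[C@@H](O)CC(=O)O)c2C(C)C)cc1` gives 15 nM, the higher of the two numbers, and its gap to compound 1 lies beyond the scatter. Compound 3 `CC(C)c1c(C(=O)NCc2ccc(Cl)cc2)nn(-c2ccc(F)cc2)c1OC[C@@H](O)C[C@@H](O)CC(=O)O` is not yet measured; it differs from compound 2 by chloro in place of methyl on an aromatic carbon. Among the compounds with values here, no step of this kind between measured compounds is known, so the expected step is small, a 1.3-fold lower number from compound 2 to compound 3 (0.10 log units; within the scatter), not beyond the scatter in either direction. Compound 3 is expected to give 12 nM in this assay, between 5 nM and 30 nM.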

Compound 3, half-maximal inhibitory concentration: 6.7 nM
The estimate for compound 3 lay 1.8-fold (0.25 log units) above the measured number, and the stated range covers the measured number.
By their numbers in this assay, from the lowest: compounds 1 and 3 (each within the scatter of the next); then compound 2.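

Exchanging 4-methylbenzyl for 4-chlorobenzyl gives a 2.2-fold lower number from compound 2 to compound 3 (0.35 log units; beyond the scatter) in this assay, the first step read at this position. The position para to a large group therefore responds to the group it carries, with a modest gain in inhibition for chloro over methyl, though this rests on a single pair. Nothing at hand accounts for the step.

From the compounds shown here alone, how fluoro, methoxy or a carboxylic acid would behave at this position remains open. Also open, going by these compounds, is whether the same exchange gives a similar step on the core of compound 1.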